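This account rests on a few compounds, and the source may have more. Where it says the series, first, only, none or still open, it means among the compounds named here.

Measured so far:
compound 1, `Cc1ccc(OCC(=O)N(Cc2cccs2)c2nccs2)cc1`: 2240 nM
compound 2, `COCCN(Cc1cccs1)C(=O)COc1ccc(C)cc1`: 400 nM

Working notes on the series. Both compounds share the same core and differ only in the group on the amide-type nitrogen. In an assay on HEK293 cells for agonist activity at transient receptor potential cation channel subfamily M member 8 (Homo sapiens), read by fluorescence and calcium flux, with a stated time of 15 min (on this read-out higher numbers stand for an effect only at larger amounts of compound and lower numbers for an effect already at smaller amounts), compound 1 gives 2240 nM, and compound 2 gives 400 nM. Within the data shown here, the single step, a 5.6-fold lower number from compound 1 to compound 2 (0.75 log units; beyond the scatter), places compound 2 as the lowest of the two numbers, with compound 1 as its nearest neighbour and beyond the scatter from it.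

Compound 3, `Cc1ccc(OCC(=O)N(O)Cc2cccs2)cc1`, is not yet measured. It differs from compound 2 as follows: hydroxy in place of 2-methoxyethyl on an amide-type nitrogen. Among the measured compounds shown here, the only step that bears on this change is the one on the same nitrogen, from compound 1 to compound 2, which was modest and shows that this position is not silent in this assay. For the measured compounds named here, no measured pair tests a hydroxy group here, and a small group that is both donor and acceptor has no precedent in the two compounds. The expectation is therefore cautious: a modest rise in the number, a 2.3-fold higher number from compound 2 to compound 3 (0.35 log units; beyond the scatter), with a wide range that also admits no change beyond the scatter. Compound 3 is estimated at 900 nM, between 250 nM and 3500 nM.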

Compound 3, half-maximal effective concentration: 8000 nM
The estimate for compound 3 lay 8.9-fold (0.95 log units) below the measured number, and the stated range ends below it.
By their numbers in this assay, from the lowest: compound 2; then compound 1; then compound 3.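

On the amide-type nitrogen, hydroxy in place of 2-methoxyethyl gives in this assay a 20-fold higher number from compound 2 to compound 3 (1.30 log units; beyond the scatter) as a large step, whereas the earlier change at this place was only modest. Hydroxy in place of 1,3-thiazol-2-yl gives a 3.6-fold higher number from compound 1 to compound 3 (0.55 log units; beyond the scatter) as a modest step in the same direction, so hydroxy gives the highest number of the three groups tested on this nitrogen, and each of the three steps lies beyond the scatter. The place therefore separates these groups clearly, but the step from 2-methoxyethyl to hydroxy changes the heavy-atom count and the hydrogen-bond donor count together, and no evidence on the compounds bears on the reason for the rise.

The compounds shown leave open whether the result follows the loss of the chain or the arrival of the hydroxy group itself, a question that 2-hydroxyethyl and methoxy on the same nitrogen could help separate. Also open, going by these compounds, is what the oxygen of 2-methoxyethyl contributes, which a plain propyl or butyl chain at this place could test.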